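Swapping the isoquinoline amide for a methylimidazole amide

The source may report more compounds than this note shows. Statements on the series, on what has been measured and on what is new or still open speak of the compounds shown alone.

Compound 1 `CCCn1c(NC(=O)c2nccc3ccccc23)nc2cc(C(N)=O)cc(OC)c21` gives > 100000 nM in an assay for activation of interferon regulatory factor 3 (Homo sapiens), read by a luciferase reporter, with a stated time of 20 h (on this read-out higher numbers stand for an effect only at larger amounts of compound and lower numbers for an effect already at smaller amounts), which is a limit of the assay and not a number.
Compound 2 `COc1cc(C(N)=O)cc2nc(NC(=O)c3nccc4ccccc34)n(CCCNC(=O)OCc3ccccc3)c12` gives > 100000 nM in this assay, again a limit and not a number.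

Compound 2 thus stands where both measured values sit, at the limit of > 100000 nM in this assay, at which 2 of the 2 values shown sit. The step that the two limits leave unreadable from compound 1 to compound 2 has both ends at a limit and so shows no readable size. Compound 3 `COc1cc(C(N)=O)cc2nc(NC(=O)c3cncn3C)n(CCCNC(=O)OCc3ccccc3)c12` differs from compound 2 by 1-methyl-1H-imidazol-5-yl in place of isoquinolin-1-yl on a carbonyl carbon. Going by the values given here, no measured step bears on this change, and the single measured step offers no size to lean on. For compound 3 a value at the same limit is therefore expected, so the step of a number no higher from compound 2 to compound 3 (the limit leaves the size open) is expected to show nothing beyond the scatter. The estimate for compound 3 is 100000 nM, between 30000 nM and 300000 nM.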

Compound 3, half-maximal effective concentration: > 100000 nM
Compound 3: only a limit was reported; the forecaster's own chance of this, stated with the estimate: 85%; the middle value sits exactly at the limit.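

Compound 2 and compound 3 both give only a limit in this assay, not a number, so the step between them cannot be read. The compounds shown leave open how isoquinolin-1-yl and 1-methyl-1H-imidazol-5-yl compare.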